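Notes on a methoxy removal in a cytotoxicity series

The compounds below may be only part of what the source reports. "The series", "measured", "known", "first", "only" and "open" are said of these compounds alone.

Working notes on the series. Compound 1 `COc1ccc(-c2cc(/C=C/C(=O)c3ccc(N)cc3)[nH]n2)cc1` and compound 2 `COc1ccc(-c2cc(/C=C/C(=O)c3ccc(N)cc3)[nH]n2)cc1OC` share one core; compound 3 `COc1cc(C(=O)/C=C/c2cc(-c3cc(OC)c(OC)c(OC)c3)n[nH]2)cc(OC)c1OC` has another, and the difference between the two cores is not broken down here. In a functional assay on RXF 393 cells (Homo sapiens) for cytotoxicity, read by sulforhodamine B assay, with a stated time of 48 h, tested at 10 uM (a lower number here means a stronger effect, a higher number a weaker effect of the compound at the concentration tested), compound 1 gives -47%, compound 2 gives -39% and compound 3 gives -88%. Compound 3 stands lowest of the three numbers, beyond the scatter against compound 1 and against compound 2. The change from compound 2 to compound 1 is hydrogen in place of methoxy on an aromatic carbon; in this assay it gave a number 8 percentage points lower from compound 2 to compound 1 (within the scatter). Compound 4 `COc1ccc(-c2cc(/C=C/C(=O)c3cc(OC)c(OC)c(OC)c3)[nH]n2)cc1OC` is not yet measured; it arises from compound 3 by hydrogen in place of methoxy on an aromatic carbon. This is the same kind of change, though the place here is also meta to a methoxy group. On this precedent the step for compound 4 in this assay is expected to be small, a number 8 percentage points higher from compound 3 to compound 4 (within the scatter). This rests on compound 3 at -88% and on the earlier step of a number 8 percentage points lower from compound 2 to compound 1 (within the scatter). Compound 4 is expected to give -80%, within a range from -100% to -55%.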

Compound 4, a percentage reported as activity, at one concentration (the size of the read-out at that concentration, not a potency): -80%
The estimate for compound 4 equals the measured number at the digits printed; low and high end bracket the measured number.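

In this assay the new step, a number 8 percentage points higher from compound 3 to compound 4 (within the scatter), is small when taken alone, and so is the earlier step on the other core. Set side by side, however, the two steps do not match: the same change on two cores in this assay, a number 8 percentage points lower (within the scatter) from compound 2 to compound 1 and a number 8 percentage points higher (within the scatter) from compound 3 to compound 4, 16 percentage points apart, beyond the scatter of two such steps

Hydrogen in place of methoxy therefore stayed a small step on both cores, but it cannot be carried from one core to the other as a single fixed number, and two pairs do not show whether the gap follows the core or the place of the change, which in compound 4 is also meta to a methoxy group. The compounds shown leave open what a hydroxy group or a longer chain such as ethoxy would give at this place in place of the methoxy. They also leave open whether taking off a further methoxy group from compound 4 would again give only a small step.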